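The source may hold more compounds than are shown below. What is called first, only, known or untested is meant among the compounds shown, and "the series" means these compounds.

In a functional assay on MCF7 cells (Homo sapiens) for antiproliferative activity, read by sulforhodamine B assay, with a stated time of 48 h (a higher number here means a weaker inhibitor, a lower number a stronger inhibitor), compound 1 `Cc1ccccc1OS(=O)(=O)c1ccc(N2CCN(C)C2=O)cc1` gives 5600 nM and compound 2 `CN1CCN(c2ccc(S(=O)(=O)Oc3cc(Cl)c(Cl)cc3Cl)cc2)C1=O` gives 630 nM. Compound 3 `CCCN1CCN(c2ccc(S(=O)(=O)Oc3ccccc3C)cc2)C1=O` gives > 100000 nM, which is a limit and not a number, so it stands at the limit of > 100000 nM in this assay, at which 1 of the 3 values shown sits.

Compound 4 `CCCN1CCN(c2ccc(S(=O)(=O)Oc3cccc(F)c3)cc2)C1=O` keeps the chain of compound 3 and alters the other end of the molecule: 3-fluorophenyl in place of 2-methylphenyl on an oxygen.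

Among the compounds with values here, the one measured step that bears on this is an at least 17-fold higher number from compound 1 to compound 3 (1.25 log units; beyond the scatter), a large move toward weaker inhibition, and compound 4 retains that change. Within the data shown here, no measured step covers the swap on the oxygen with this chain in place. Still, compound 2 gives 630 nM and compound 1 gives 5600 nM, so the number for compound 2 reads lower and the group on that oxygen can matter. A modest recovery is therefore plausible, while the retained chain argues for weak inhibition.

The expected step is toward a lower number, an at least 3.3-fold lower number from compound 3 to compound 4 (0.52 log units; beyond the scatter). For compound 4 the estimate is 30000 nM, with an expected range from 8000 nM to 100000 nM.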

Compound 4, half-maximal inhibitory concentration: 24000 nM
For compound 4 the middle estimate is 1.3-fold (0.10 log units) above the measured one; low and high end bracket the measured number.
By their numbers in this assay, from the lowest: compound 2; then compound 1; then compound 4. At a limit, above all of these: compound 3.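

With the chain of compound 3 kept, the group on the oxygen bound to the sulfonyl sulfur still counts: in this assay, 3-fluorophenyl in place of 2-methylphenyl brings an at least 4.1-fold lower number from compound 3 to compound 4 (0.61 log units; beyond the scatter). Within the data shown here, that chain therefore does not by itself rule out a measurable number, which the earlier compounds could not show. The starting point of this step is a limit and not a number, held by compound 3: the limit of > 100000 nM in this assay, at which 1 of the 4 values shown sits.

Because two things change at once on that ring, the loss of the methyl and the gain of the fluorine cannot be told apart here, and an unsubstituted phenyl on the same oxygen would separate them. As far as these compounds go, whether other groups on that ring, such as a methoxy or a nitrile, would bring the number lower with this chain also stays open.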